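This account rests on a few compounds, and the source may have more. Where it says the series, first, only, none or still open, it means among the compounds named here.

Measured compounds:
Compound 1 `COc1cc(/C=C/C(=O)/C=C/c2cc(OC)c(OC)c(OC)c2)ccc1OCc1cn(CCCCCOc2cc(=O)oc3ccccc23)nn1`: in a functional assay on COLO 205 cells (Homo sapiens) for inhibition, read by sulforhodamine B assay, with a stated time of 48 h, tested at 50 uM (on this read-out lower numbers stand for less inhibition of growth and higher numbers for more inhibition of growth at the one concentration tested), compound 1 gives 51%.
Compound 2 `COc1ccc(/C=C/C(=O)/C=C/c2ccc(OCc3cn(CCOc4cc(=O)oc5ccccc45)nn3)c(OC)c2)cc1`: in this assay compound 2 gives 68%.
Compound 3 `COc1cccc(/C=C/C(=O)/C=C/c2ccc(OCc3cn(CCCCCOc4cc(=O)oc5ccccc45)nn3)c(OC)c2)c1`: in this assay compound 3 gives 34%.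

Compound 2 stands highest of the three numbers, with compound 1 nearest and compound 3 furthest, both beyond the scatter. Compound 4 `COc1cc(/C=C/C(=O)/C=C/c2ccco2)ccc1OCc1cn(CCOc2cc(=O)oc3ccccc23)nn1` is not yet measured; it differs from compound 2 as follows: furan-2-yl in place of 4-methoxyphenyl on a double-bonded chain carbon bound to a double-bonded chain carbon. Within the data shown here, the one measured step at this place is a number 17 percentage points lower from compound 1 to compound 3 (beyond the scatter), which exchanged the group on a double-bonded chain carbon bound to a double-bonded chain carbon and lowered the number beyond the scatter. The present exchange sits at the same place, though the groups differ, so a downward step of similar size is expected: a number 18 percentage points lower from compound 2 to compound 4 (beyond the scatter). Compound 4 is therefore estimated at 50% in this assay, between 30% and 70%.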

Compound 4, percent growth inhibition at one concentration: 68%
Estimate against measurement, compound 4: 18 percentage points below, and the stated range covers the measured number.
By their numbers in this assay, from the lowest: compound 3; then compound 1; then compounds 2 and 4 (each within the scatter of the next).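

In this assay, furan-2-yl in place of 4-methoxyphenyl on a double-bonded chain carbon bound to a double-bonded chain carbon gives no change at the digits printed from compound 2 to compound 4 (within the scatter), so an exchange at this place need not lower the number. Among these compounds, the one earlier step here, a number 17 percentage points lower from compound 1 to compound 3 (beyond the scatter), therefore does not hold for every exchange at this place. No supporting data bear on why the two exchanges differ.

Still open, going by these compounds, is how a carboxylic acid or an amine would read at this place. Also open, on these data alone, is whether furan-2-yl gives the same result on the longer chain of compound 1 .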